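This account rests on a few compounds, and the source may have more. Where it says the series, first, only, none or still open, it means among the compounds named here.

Working notes on the series.

Compound 1 `N#CC1=C(N)Oc2c(c3nc4ccccc4nc3c3ccccc23)C12C(=O)N(Cc1cnnn1-c1ccc(Cl)cc1)c1ccccc12` and compound 2 `N#CC1=C(N)Oc2c(c3nc4ccccc4nc3c3ccccc23)C12C(=O)N(Cc1cnnn1-c1ccc(N)cc1)c1ccccc12` share the core and differ by amino in place of chloro on an aromatic carbon. In a functional assay on HepG2 cells (Homo sapiens) for antiproliferative activity, read by MTT assay, with a stated time of 48 h (on this read-out lower numbers stand for stronger inhibition and higher numbers for weaker inhibition), compound 1 gives only a limit, > 50000 nM. In this assay compound 2 likewise gives only a limit, > 50000 nM. The step that the two limits leave unreadable from compound 1 to compound 2 therefore cannot be read in either direction. Compound 3 `COc1ccccc1-n1nncc1CN1C(=O)C2(C(C#N)=C(N)Oc3c(N)cc4nc5ccccc5nc4c32)c2ccccc21` carries a different group on the aromatic nitrogen of the five-membered ring; in this assay compound 3 also gives only a limit, > 50000 nM. For the measured compounds named here, all three values so far sit at the limit of > 50000 nM in this assay, at which 3 of the 3 values shown sit, so no numbered step is available anywhere in the set.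

Compound 4 `N#CC1=C(N)Oc2c(N)cc3nc4ccccc4nc3c2C12C(=O)N(Cc1cnnn1-c1ccc([N+](=O)[O-])cc1[N+](=O)[O-])c1ccccc12` is the next member to be measured. It differs from compound 3 by 2,4-dinitrophenyl in place of 2-methoxyphenyl on an aromatic nitrogen. Going by the values given here, no measured step bears on this change, since the only pair that differs in one place, compound 1 to compound 2, is unreadable for the reasons given. With every shown value at the limit, compound 4 is expected to give a result at or near that limit as well, so the expected step of a number no higher from compound 3 to compound 4 (the limit leaves the size open) is essentially none that can be read. The estimate for compound 4 in this assay is 50000 nM, with a range from 15000 nM to 100000 nM.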

Compound 4, half-maximal inhibitory concentration: 18400 nM
Compound 4: middle estimate off by 2.7-fold (0.43 log units), on the high side, within the range that was stated.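

Working notes, continued. In this assay, for the compounds shown here, 2,4-dinitrophenyl in place of 2-methoxyphenyl on the aromatic nitrogen of the five-membered ring gives an at least 2.7-fold lower number from compound 3 to compound 4 (0.43 log units; beyond the scatter), the first step that can be read. Substitution at this position can therefore move the read-out away from the limit, and compound 4 is the only compound shown with a number rather than a limit: the limit of > 50000 nM in this assay, at which 3 of the 4 values shown sit. Compound 3 gives > 50000 nM, which is a limit and not a number, so the step gives only a minimum size.

The compounds shown do not separate the two nitro groups, so it stays open whether a single nitro group or an unsubstituted phenyl on this nitrogen would give a similar step. Also open, on these data alone, is whether 2,4-dinitrophenyl would give a step on the core of compound 1, since the chloro to amino step on that core cannot be read and the shared core of compound 3 and compound 4 is the only setting in which the change appears.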